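A few compounds are considered here, and "the series" means these few. Any claim that something is new, unique, unknown or untested is made for them only; others in the source may bear on it.

Compound 1 `COc1cc(C(O)C(CO)Oc2c(OC)cc([C@@H]3OC[C@@H]4[C@H]3CO[C@H]4c3ccc(O)c(OC)c3)cc2OC)ccc1O` and compound 2 `COc1cc([C@@H]2Oc3c(OC)cc(/C=C/C=O)cc3[C@H]2CO)ccc1O` have both been measured in a functional assay on BV-2 cells (Mus musculus) for inhibition, read by Griess assay, with a stated time of 24 h; on this read-out higher numbers stand for weaker inhibition and lower numbers for stronger inhibition. In this assay compound 1 gives 19300 nM, while compound 2 gives 7070 nM, the lowest of the two numbers, and the step between compound 1 and compound 2 lies beyond the scatter. Compound 3 `COc1cc([C@@H]2Oc3c(OC)cc(/C=C/C=O)cc3[C@H]2CO)cc(OC)c1O` is not yet measured; it differs from compound 2 by methoxy in place of hydrogen on an aromatic carbon. Among the measured compounds shown here, no step between measured compounds matches this change, so the expected shift from compound 2 to compound 3 in this assay is a 1.0-fold lower number from compound 2 to compound 3 (0.00 log units; within the scatter), not beyond the scatter in either direction. Compound 3 is estimated at 7000 nM, in a range from 3500 nM to 14000 nM.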

Compound 3, half-maximal inhibitory concentration: 10000 nM
The estimate for compound 3 lay 1.4-fold (0.15 log units) below the measured number; the measured number falls inside the stated range.
By their numbers in this assay, from the lowest: compounds 2, 3 and 1 (each within the scatter of the next, the first and the last beyond it).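

In this assay, placing methoxy in place of hydrogen on an aromatic carbon, ortho to a hydroxy group, gives a 1.4-fold higher number from compound 2 to compound 3 (0.15 log units; within the scatter) and so leaves compound 2 and compound 3 within the scatter of each other. Among the compounds shown here, this is the first sign that this position accepts a methoxy group without a change that this read-out can separate from scatter. Nothing available explains this result.

On these data alone, whether an ethoxy group, an amine or a carboxylic acid at this position would also stay within the scatter remains open. A single step also cannot show whether methoxy would behave the same way at other aromatic positions.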